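The source may hold more compounds than are shown below. What is called first, only, known or untested is meant among the compounds shown, and "the series" means these compounds.

Compound 2 `CC(=O)C[C@H]1O[C@@H](On2cc(CN3C(=O)/C(=N\Nc4ccc(Br)cc4)c4ccccc43)nn2)[C@H](OC(C)=O)[C@@H](OC(C)=O)[C@@H]1OC(C)=O` is the starting point. In an ADME assay on Vero cells (Chlorocebus sabaeus) for cytotoxicity, read by fluorescence and resazurin assay, with a stated time of 3 days (a lower number here means that less compound is tolerated, a higher number that more compound is tolerated), compound 2 gives 116000 nM. Within the data shown here, its only measured neighbour, compound 1 `CC(=O)C[C@H]1O[C@@H](On2cc(CN3C(=O)/C(=N\Nc4ccccc4)c4ccccc43)nn2)[C@H](OC(C)=O)[C@@H](OC(C)=O)[C@@H]1OC(C)=O`, gives 108000 nM in this assay, and the two numbers sit within the scatter of each other, the only measured step being a 1.1-fold higher number from compound 1 to compound 2 (0.03 log units; within the scatter). Compound 3 `CC(=O)C[C@H]1O[C@@H](On2cc(CN3C(=O)/C(=N\Nc4cccc(Cl)c4)c4ccccc43)nn2)[C@H](OC(C)=O)[C@@H](OC(C)=O)[C@@H]1OC(C)=O` carries 3-chlorophenyl in place of 4-bromophenyl on an amine nitrogen. Among the measured compounds shown here, that earlier step is the only one bearing on this change, and it was small, so the step of a 1.0-fold lower number from compound 2 to compound 3 (0.02 log units; within the scatter) is expected to stay within the scatter. Compound 3 is therefore estimated at 112000 nM, with a range from 56000 nM to 224000 nM.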

Compound 3, half-maximal cytotoxic concentration: 117000 nM
Beside the measured number, compound 3's estimate is 1.0-fold (0.02 log units) below it, and the stated range covers the measured number.
By their numbers in this assay, from the lowest: compounds 1, 2 and 3 (each within the scatter of the next).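

In this assay, placing 3-chlorophenyl where 4-bromophenyl stood on the amine nitrogen gives a 1.0-fold higher number from compound 2 to compound 3 (0.00 log units; within the scatter), while chloro in place of hydrogen on the aromatic carbon gives a 1.1-fold higher number from compound 1 to compound 3 (0.03 log units; within the scatter). The phenyl, 4-bromophenyl and 3-chlorophenyl groups therefore cannot be told apart at this place in this assay. No supporting measurement accompanies this result, so no cause can be named.

Still open, going by these compounds, is whether a phenyl ring carrying an amine or a carboxylic acid would stay within this range, and whether a longer chain in place of the ring would.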